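Hydroxy for Nitro on an Aryl Hydrazone Tail

The compounds below may be only part of what the source reports. "The series", "measured", "known", "first", "only" and "open" are said of these compounds alone.

Three compounds share a core carrying a hydrazone tail. Compound 1 `O=C(CCc1nc2ccccc2c(=O)[nH]1)N/N=C/c1ccc([N+](=O)[O-])cc1` gives 220000000 nM in a physicochemical assay, read by spectrophotometry, with a stated time of 6 min; on this read-out lower numbers stand for stronger inhibition and higher numbers for weaker inhibition. Compound 2 `O=C(CCCc1nc2ccccc2c(=O)[nH]1)N/N=C/c1ccc([N+](=O)[O-])cc1` gives 270000000 nM, a number that sits within the scatter of compound 1. Compound 3 `COc1cc(/C=N/NC(=O)CCc2nc3ccccc3c(=O)[nH]2)cc(OC)c1O` gives 105000000 nM, a lower number that lies beyond the scatter, so among these three compound 1 stands with compound 2 at the weaker end. Compound 4 `O=C(CCc1nc2ccccc2c(=O)[nH]1)N/N=C/c1ccc(O)cc1` is not yet measured; it differs from compound 1 by hydroxy in place of nitro on an aromatic carbon. Among the measured compounds shown here, no measured pair shows this change. The lower number of compound 3, which also carries a hydroxy, at 105000000 nM hints at a modest drop, so a small step of a 1.5-fold lower number from compound 1 to compound 4 (0.17 log units; within the scatter) is expected. Compound 4 is estimated at 150000000 nM, within 70000000 nM to 320000000 nM.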

Compound 4, half-maximal inhibitory concentration: 105000000 nM
Compound 4: middle estimate off by 1.4-fold (0.15 log units), on the high side; the measured number falls inside the stated range.
By their numbers in this assay, from the lowest: compounds 3 and 4 (each within the scatter of the next); then compounds 1 and 2 (each within the scatter of the next).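

On an aromatic carbon para to a large group, hydroxy in place of nitro gives a 2.1-fold lower number from compound 1 to compound 4 (0.32 log units; beyond the scatter), a modest move toward stronger inhibition. Among the compounds shown here, this is the first reading of a single change at this position, and it shows that the swap from 4-nitrophenyl to 4-hydroxyphenyl alone shifts the number while the rest of the molecule stays the same. No measurement shown here accounts for the shift. Going by these compounds, whether an amine or a carboxylic acid on the same carbon would lower the number further remains open. So does whether the same swap gives a similar step on the longer chain of compound 2.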